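From a Protected Amine to an Ethylpyrimidine

A few compounds are considered here, and "the series" means these few. Any claim that something is new, unique, unknown or untested is made for them only; others in the source may bear on it.

In a functional assay on cells for agonist activity at Glucose-dependent insulinotropic receptor (Homo sapiens), read by HTRF and cAMP accumulation, with a stated time of 30 min (on this read-out higher numbers stand for an effect only at larger amounts of compound and lower numbers for an effect already at smaller amounts), compound 1 `CC(C)(C)OC(=O)N1CCC2(CC1)CC2CCOc1ccc(S(C)(=O)=O)cc1` gives 2390 nM, compound 2 `CC(C)(C)OC(=O)N1CCC2(CC1)CC(CCCOc1ccc(S(C)(=O)=O)cc1)C2` gives 14 nM, and compound 3 `CC(C)(C)OC(=O)N1CCC2(CC1)CC(CCCOc1ccc(S(C)(=O)=O)cc1F)C2` gives 25 nM. Compound 3 thus stands second highest of the three numbers, close to compound 2 and far from compound 1; the step of a 1.8-fold higher number from compound 2 to compound 3 (0.25 log units; within the scatter) lies within the scatter. Compound 4 `CCc1cnc(N2CCC3(CC2)CC(CCCOc2ccc(S(C)(=O)=O)cc2F)C3)nc1` differs from compound 3 in one place: 5-ethylpyrimidin-2-yl in place of tert-butoxycarbonyl on an amine nitrogen in a ring. Among the measured compounds shown here, none of the measured steps changes the group on this amine nitrogen, so no measured step bears directly on this change, and the estimate rests on the structural change alone. The step of a 3.1-fold lower number from compound 3 to compound 4 (0.49 log units; beyond the scatter) is expected to give a lower number. Compound 4 is therefore estimated at 8 nM, with a range from 1.5 nM to 40 nM.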

Compound 4, half-maximal effective concentration: 225 nM
Compound 4: the middle estimate sits 28-fold (1.45 log units) below what was measured, outside the stated range (above it).
By their numbers in this assay, from the lowest: compounds 2 and 3 (each within the scatter of the next); then compound 4; then compound 1.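

The group on this amine nitrogen matters: 5-ethylpyrimidin-2-yl in place of tert-butoxycarbonyl gives a 9.0-fold higher number from compound 3 to compound 4 (0.95 log units; beyond the scatter). The two groups count the same hydrogen-bond acceptors and no donors, yet they are not interchangeable at this position, so those counts alone do not settle the outcome here. No measurement at hand explains this step. Still open, from the compounds shown here alone, is whether the ethyl group or the pyrimidine ring itself governs the result. A 5-methylpyrimidin-2-yl or an unsubstituted pyrimidin-2-yl group on the same nitrogen would help separate the two.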